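This account rests on a few compounds, and the source may have more. Where it says the series, first, only, none or still open, it means among the compounds named here.

Working notes on the series. Three compounds have numbers in a physicochemical assay for lipophilicity, read by HPLC, in phosphate buffer, measured as octanol-water partition, at pH 7.4; on this read-out lower numbers stand for lower lipophilicity and higher numbers for higher lipophilicity. Compound 1 `CC(=O)N[C@@H](C)C(=O)N(C)/N=N/c1ccc(C(N)=O)cc1` gives 0.69 in this assay. Compound 2 `CC(=O)NCC(=O)N(C)/N=N/c1ccc(C#N)cc1` gives 1.1. Compound 3 `CCCC(=O)N[C@@H](C)C(=O)N(C)/N=N/c1ccc(C#N)cc1` gives 2.28, the highest of the three; its nearest neighbour is compound 2, and the gap to compound 1 is the widest, both gaps beyond the scatter.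

Compound 4 `CC(=O)N[C@@H](C)C(=O)N(C)/N=N/c1ccc(C#N)cc1` is not yet measured. It differs from compound 3 by hydrogen in place of ethyl on a saturated chain carbon bound to a carbonyl carbon. Within the data shown here, no pair of measured compounds with this exact change is available. A shortening of the acyl chain of this size is expected to lower the number in this assay by a step beyond the scatter, estimated as a number 0.88 log units lower from compound 3 to compound 4 (beyond the scatter). For compound 4 the expected value is 1.4, within the range 1 to 1.8.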

Compound 4, partition coefficient: 1.41
Compound 4: middle estimate off by 0.01 log units, on the low side; low and high end bracket the measured number.
By their numbers in this assay, from the lowest: compound 1; then compound 2; then compound 4; then compound 3.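

In this assay compound 4 links the series through single changes at three places. The series shows a number 0.87 log units lower from compound 3 to compound 4 (beyond the scatter) with hydrogen in place of ethyl on a saturated chain carbon bound to a carbonyl carbon, a number 0.31 log units higher from compound 2 to compound 4 (beyond the scatter) with methyl in place of hydrogen on a saturated chain carbon bound to an amide-type nitrogen and a carbonyl carbon, and a number 0.72 log units higher from compound 1 to compound 4 (beyond the scatter) with cyano in place of carbamoyl on an aromatic carbon. Each change rests on one pair only.

On these data alone, a longer chain than propylcarbonyl, or a carboxylic acid in place of cyano on the aromatic carbon, stays open. Nothing shown accounts for any of these steps.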